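Compound 4 on a series that sits at the assay limit

The source may report more compounds than this note shows. Statements on the series, on what has been measured and on what is new or still open speak of the compounds shown alone.

Compound 3 `O=C(c1ccccc1F)N1CC(c2nc(-c3cccc(Cl)c3)no2)C1` is one of three compounds with the shared core tested in an assay on HEK293 cells for positive allosteric modulation of metabotropic glutamate receptor 5 (Homo sapiens), read by FLIPR; on this read-out higher numbers stand for an effect only at larger amounts of compound and lower numbers for an effect already at smaller amounts. In this assay compound 3 gives only a limit, > 10000 nM. Compound 1 `O=C(C1CCCO1)N1CC(c2nc(-c3cccc(Cl)c3)no2)C1` likewise gives only a limit, > 10000 nM. Compound 2 `O=C(C1CCC1)N1CC(c2nc(-c3cccc(Cl)c3)no2)C1` also sits at a limit, > 10000 nM. All three share (the limit of > 10000 nM in this assay, at which 3 of the 3 values shown sit), so the steps a step that the two limits leave unreadable from compound 1 to compound 2, a step that the two limits leave unreadable from compound 1 to compound 3 and a step that the two limits leave unreadable from compound 2 to compound 3 give no readable size or direction. Compound 4 `CC1CCN(C(=O)N2CC(c3nc(-c4cccc(Cl)c4)no3)C2)CC1` differs from compound 3 by 4-methylpiperidin-1-yl in place of 2-fluorophenyl on a carbonyl carbon. Going by the values given here, no measured step bears on this change with a readable size, so for compound 4 the expected step is a step that the limit leaves unreadable from compound 3 to compound 4, with no direction claimed. Compound 4 is therefore estimated at 15000 nM, between 3000 nM and 100000 nM, most likely again only a limit.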

Compound 4, half-maximal effective concentration: 865 nM
Compound 4: the middle estimate sits 17-fold (1.24 log units) above what was measured, and the stated range ends above it.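

In this assay, the place on the carbonyl carbon now yields a readable change: 4-methylpiperidin-1-yl in place of 2-fluorophenyl gives an at least 11-fold lower number from compound 3 to compound 4 (1.06 log units; beyond the scatter). The same group gives an at least 11-fold lower number from compound 2 to compound 4 (1.06 log units; beyond the scatter) in place of cyclobutyl and an at least 11-fold lower number from compound 1 to compound 4 (1.06 log units; beyond the scatter) in place of oxolan-2-yl, so all three earlier groups compare with it in one direction. The steps among those three compounds cannot be read: the limit of > 10000 nM in this assay, at which 3 of the 4 values shown sit.

From the compounds shown here alone, whether the methyl group of compound 4 matters stays open. So does whether piperidin-1-yl without the methyl, morpholin-4-yl or an open-chain diethylamino group on this carbonyl carbon would give a measurable value.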